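The source may report more compounds than this note shows. Statements on the series, on what has been measured and on what is new or still open speak of the compounds shown alone.

Compound 1 `CCN(C(=O)c1cc(C)ccc1-n1nccn1)[C@H](C)Cn1ccc(-c2ccc(F)cn2)n1`: 250 nM
Compound 2 `Cc1ccc(-n2nccn2)c(C(=O)N[C@@H](C)Cn2cc(-c3ccc(F)cn3)cn2)c1`: 840 nM
Compound 3 `Cc1ccc(-n2nccn2)c(C(=O)N(C)[C@@H](C)Cn2cc(-c3ccc(F)cn3)cn2)c1`: 21.2 nM

In a functional assay on cells for antagonist activity at Orexin receptor type 2 (Homo sapiens), read by fluorescence and calcium flux, with a stated time of 30 min (on this read-out higher numbers stand for weaker inhibition and lower numbers for stronger inhibition), compound 3 gives the lowest number of the three; compound 1 sits higher at 250 nM and compound 2 higher still at 840 nM, both gaps beyond the scatter. The unmeasured compound 4 `CCN(C(=O)c1cc(C)ccc1-n1nccn1)[C@@H](C)Cn1cc(-c2ccc(F)cn2)cn1` differs from compound 3 by methyl in place of hydrogen on a saturated chain carbon bound to an amide-type nitrogen. Among the measured compounds shown here, the one measured step touching this part of the molecule is a 40-fold lower number from compound 2 to compound 3 (1.60 log units; beyond the scatter), a large change, but it concerns the amide nitrogen itself, not the chain on it. Compound 1 carries the ethyl yet differs from compound 3 in more than one place, so its value alone cannot set the size. A modest shift, within or near the scatter, is expected for compound 4: a 1.5-fold higher number from compound 3 to compound 4 (0.18 log units; within the scatter). Compound 4 is estimated at 32 nM, between 10 nM and 110 nM.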

Compound 4, half-maximal inhibitory concentration: 5.87 nM
Beside the measured number, compound 4's estimate is 5.5-fold (0.74 log units) above it, outside the stated range (below it).
By their numbers in this assay, from the lowest: compound 4; then compound 3; then compound 1; then compound 2.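

In this assay the methyl to ethyl change on the amide-type nitrogen gives a 3.6-fold lower number from compound 3 to compound 4 (0.56 log units; beyond the scatter) and so shows that the gain at this nitrogen did not end with methyl. Measured from the amide hydrogen, ethyl gives a 140-fold lower number from compound 2 to compound 4 (2.16 log units; beyond the scatter) and goes beyond the methyl step of a 40-fold lower number from compound 2 to compound 3 (1.60 log units; beyond the scatter) on the same nitrogen. No evidence at hand says why the extra carbon has this effect. The compounds shown leave open whether a longer chain such as propyl, or a cyclopropyl ring, would lower the number further on this nitrogen. They also leave open how an amine or a hydroxyl at the end of that chain would read.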